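Working notes: 2,3-dichlorophenyl to 3-chloro-4-hydroxyphenyl

The source may report more compounds than this note shows. Statements on the series, on what has been measured and on what is new or still open speak of the compounds shown alone.

In a functional assay on A549 cells (Homo sapiens) for cytotoxicity, read by MTT assay, with a stated time of 72 h (a higher number here means a weaker inhibitor, a lower number a stronger inhibitor), compound 1 `COc1cccc(/C=C2\CCC/C(=C\c3cccc(OC)c3OC)C2=O)c1` gives 16400 nM. Compound 2 `COc1cccc(/C=C2\CCC/C(=C\c3cccc(Cl)c3Cl)C2=O)c1OC` reads > 20000 nM in this assay, which is a limit of the assay and not a number (the limit of > 20000 nM in this assay, at which 1 of the 2 values shown sits). Going by the values given here, the single measured step, an at least 1.2-fold higher number from compound 1 to compound 2 (0.08 log units; that floor lies within the scatter), has a floor within the scatter, so it fixes no firm size for a change at this place.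

Compound 3 `COc1cccc(/C=C2\CCC/C(=C\c3ccc(O)c(Cl)c3)C2=O)c1OC` differs from compound 2 by 3-chloro-4-hydroxyphenyl in place of 2,3-dichlorophenyl on a double-bonded chain carbon bound to a double-bonded ring carbon. The 3-chloro-4-hydroxyphenyl group enters on a double-bonded chain carbon bound to a double-bonded ring carbon, where 2,3-dichlorophenyl stood. Among the compounds with values here, no measured compound carries this group, so the data give no direct reading of it. Within the data shown here, the only number is that of compound 1 at 16400 nM, and the expectation is anchored there. A modest move toward a lower number in this assay is expected, not a large one. The estimated change is an at least 1.8-fold lower number from compound 2 to compound 3 (0.25 log units; that floor lies within the scatter). Compound 3 is expected at 11000 nM, with an estimated range of 4000 nM to 20000 nM.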

Compound 3, half-maximal inhibitory concentration: > 20000 nM
Compound 3: no number, only a limit; the forecaster's own chance of this, stated with the estimate: 25%; middle value at least 1.8-fold (0.25 log units) from the limit.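

In this assay compound 3 gives > 20000 nM, which is a limit of the assay and not a number. Going by these compounds alone, the one readable new step is an at least 1.2-fold higher number from compound 1 to compound 3 (0.08 log units; that floor lies within the scatter), so a second replacement of 3-methoxyphenyl on a double-bonded chain carbon bound to a double-bonded ring carbon still fixes no firm size for a change at this place. The step between compound 2 and compound 3 cannot be read, and the entry of 3-chloro-4-hydroxyphenyl for 2,3-dichlorophenyl adds a second group at this place that yields only a limit, leaving compound 1 as the sole numerical anchor in the series: the limit of > 20000 nM in this assay, at which 2 of the 3 values shown sit.

Open, on these data alone, is how far compound 2 and compound 3 lie beyond the limit, and therefore whether 2,3-dichlorophenyl and 3-chloro-4-hydroxyphenyl differ at all in this read-out. Also open, as far as these compounds go, is whether a phenyl group carrying an amine or a carboxylic acid at this place would return a number rather than a limit.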